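From 2-bromophenyl to 4-bromophenyl: expectation for compound 4

The compounds below may be only part of what the source reports. "The series", "measured", "known", "first", "only" and "open" are said of these compounds alone.

In a functional assay (a higher number here means a weaker inhibitor, a lower number a stronger inhibitor), compound 1 `CC(C)=CCOc1cc(O)c2c(c1)OC(c1cccc(F)c1)CC2=O` gives 7240 nM, compound 2 `CC(C)=CCOc1cc(O)c2c(c1)OC(c1ccc(Cl)cc1)CC2=O` gives 7020 nM and compound 3 `CC(C)=CCOc1cc(O)c2c(c1)OC(c1ccccc1Br)CC2=O` gives 3820 nM. Compound 3 cannot be separated from the other two, since the steps to it are a 1.9-fold lower number from compound 1 to compound 3 (0.28 log units; within the scatter) and a 1.8-fold lower number from compound 2 to compound 3 (0.26 log units; within the scatter).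

Compound 4 `CC(C)=CCOc1cc(O)c2c(c1)OC(c1ccc(Br)cc1)CC2=O` departs from compound 3 in one place: 4-bromophenyl in place of 2-bromophenyl on a saturated ring carbon, with 4-bromophenyl in place of 2-bromophenyl on a saturated ring carbon. Within the data shown here, no measured pair moves a single halogen while keeping it the same, so the evidence is indirect. Compound 2 is the nearest measured analogue, carrying 4-chlorophenyl, and its step to compound 3 is the one above. The remaining measured step, a 1.0-fold lower number from compound 1 to compound 2 (0.01 log units; within the scatter), is equally small. With every measured step inside the scatter, no step beyond the scatter is expected in this assay.

The expected step is a 1.6-fold higher number from compound 3 to compound 4 (0.20 log units; within the scatter). Compound 4 is estimated at 6000 nM, with an expected range of 3000 nM to 12000 nM.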

Compound 4, half-maximal inhibitory concentration: 2770 nM
Beside the measured number, compound 4's estimate is 2.2-fold (0.34 log units) above it; the measured number lies below the stated range.
By their numbers in this assay, from the lowest: compounds 4, 3, 2 and 1 (each within the scatter of the next, the first and the last beyond it).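

In this assay 4-bromophenyl in place of 2-bromophenyl on a saturated ring carbon stays within the scatter (a 1.4-fold lower number from compound 3 to compound 4 (0.14 log units; within the scatter)), so this pair does not resolve where the bromine sits on this ring. Bromo in place of chloro on an aromatic carbon gives one of the first steps in the series beyond the scatter, though a modest one (a 2.5-fold lower number from compound 2 to compound 4 (0.40 log units; beyond the scatter)), and 4-bromophenyl in place of 3-fluorophenyl gives another (a 2.6-fold lower number from compound 1 to compound 4 (0.42 log units; beyond the scatter)). Compound 4 is thus separated from compound 1 and compound 2, which compound 3 was not.

The compounds shown carry only a halogen on this ring, so the effect of a methoxy group, an amine or a carboxylic acid there remains open. No measurement is at hand to explain any of these steps.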